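A Methoxy Group Added to a Limit-Bound Compound

This account rests on a few compounds, and the source may have more. Where it says the series, first, only, none or still open, it means among the compounds named here.

Compound 1 `COc1ccc(/C=C2\CCC/C(=C\c3ccc(Br)cc3)C2=O)cc1OC` and compound 2 `COc1ccc(/C=C2\CCC/C(=C\c3ccc(O)cc3)C2=O)cc1OC` share one core and differ at a single aromatic carbon. In a functional assay on A549 cells (Homo sapiens) for cytotoxicity, read by MTT assay, with a stated time of 72 h (on this read-out higher numbers stand for weaker inhibition and lower numbers for stronger inhibition), compound 1 gives 16000 nM. Compound 2 reaches only a limit of the assay, > 20000 nM, so its exact number is not known. The step of an at least 1.2-fold higher number from compound 1 to compound 2 (0.09 log units; that floor lies within the scatter) therefore rests on that limit of > 20000 nM in this assay, at which 1 of the 2 values shown sits, and cannot be sized beyond the scatter.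

Compound 3 `COc1cc(/C=C2\CCC/C(=C\c3ccc(OC)c(OC)c3)C2=O)ccc1O` differs from compound 2 by methoxy in place of hydrogen on an aromatic carbon; cut one bond further out, the same change reads 4-hydroxyphenyl to 4-hydroxy-3-methoxyphenyl. Going by the values given here, no measured step involves a methoxy entering in place of hydrogen, so the only measured step, from bromo to hydroxy, gives no direct guidance, and it was itself within the scatter. Among the compounds with values here, with compound 2 at the assay limit and no precedent pointing either way, no step beyond the scatter is expected in this assay, and compound 3 is expected to sit at or near the limit as well. The estimated step is a step that the limit leaves unreadable from compound 2 to compound 3. Compound 3 is estimated at 25000 nM, within 10000 nM to 60000 nM.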

Compound 3, half-maximal inhibitory concentration: 10300 nM
Compound 3: the middle estimate sits 2.4-fold (0.39 log units) above what was measured; the range from low to high includes it.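

In this assay, putting a methoxy group on the aromatic carbon ortho to the hydroxy group turns 4-hydroxyphenyl into 4-hydroxy-3-methoxyphenyl, and compound 3 gives a readable number where compound 2 gave only a limit of the assay. Going by these compounds alone, this is the first look at a group entering at this carbon, and the step reads an at least 1.9-fold lower number from compound 2 to compound 3 (0.28 log units; that floor lies within the scatter). Only a floor can be stated, and the true size stays unknown, because one end of the step is a limit rather than a number: the limit of > 20000 nM in this assay, at which 1 of the 3 values shown sits.

The comparison with the bromo compound is fully readable and shows a 1.6-fold lower number from compound 1 to compound 3 (0.19 log units; within the scatter), so the 4-hydroxy-3-methoxyphenyl group of compound 3 and the 4-bromophenyl group of compound 1 cannot be told apart on this read-out.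

From the compounds shown here alone, whether an ethoxy group, a chlorine atom or an amine on that same aromatic carbon would read like methoxy remains open. Also open, going by these compounds, is how far compound 2 truly lies from compound 3, and so whether the methoxy step reaches beyond the scatter at all.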